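A few compounds are considered here, and "the series" means these few. Any claim that something is new, unique, unknown or untested is made for them only; others in the source may bear on it.

Three compounds have been run in an ADME assay on NCM460 cells (Homo sapiens) for cytotoxicity, read by MTT assay, with a stated time of 72 h; on this read-out higher numbers stand for weaker inhibition and lower numbers for stronger inhibition. Compound 1 `Cc1ccc(N2C(=O)C/C(=C\c3cccc(C(=O)Nc4cccc(F)c4)c3)C2=O)cc1` returns only a limit there, > 100000 nM. Compound 2 `Cc1ccc(NC(=O)c2cccc(/C=C3\CC(=O)N(c4ccccc4)C3=O)c2)cc1C` likewise reaches only a limit, > 100000 nM. Compound 3 `CCOc1ccc(NC(=O)c2cccc(/C=C3\CC(=O)N(Cc4ccccc4)C3=O)c2)cc1` also gives a limit, > 100000 nM. Compound 2 therefore stands where every measured compound stands, since (the limit of > 100000 nM in this assay, at which 3 of the 3 values shown sit). Compound 4 `CSc1cccc(NC(=O)c2cccc(/C=C3\CC(=O)N(c4ccccc4)C3=O)c2)c1` differs from compound 2 in one place: 3-(methylsulfanyl)phenyl in place of 3,4-dimethylphenyl on an amide-type nitrogen. Going by the values given here, no step between measured compounds is available to guide the comparison, so one expects no change beyond the usual scatter for the step that the limit leaves unreadable from compound 2 to compound 4 in this assay, and most likely another limit rather than a number. Compound 4 is accordingly estimated at 120000 nM in this assay, with a range from 50000 nM to 300000 nM.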

Compound 4, half-maximal inhibitory concentration: > 100000 nM
Compound 4 gave a limit, no number; the forecaster's own chance of this, stated with the estimate: 85%; the middle value is on the limit's open side.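

Compound 2 and compound 4 both stop at a limit in this assay, so no step can be read between them: the limit of > 100000 nM in this assay, at which 4 of the 4 values shown sit.

The compounds shown leave open whether 3-(methylsulfanyl)phenyl and 3,4-dimethylphenyl differ at all on these cells.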